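A few compounds are considered here, and "the series" means these few. Any claim that something is new, unique, unknown or untested is made for them only; others in the source may bear on it.

For the measured compounds named here, compound 3 `Cc1nn(-c2ncnc3nc[nH]c23)c2c1C(C(=O)N(C)c1ccccc1)CC(=O)N2` gives 32 nM in a functional assay on HEK293 cells for agonist activity at G-protein coupled receptor 39 (Homo sapiens), read by scintillation proximity assay and inositol phosphate accumulation, with a stated time of 75 min, in the presence of a further agent that is not named here (on this read-out lower numbers stand for an effect already at smaller amounts and higher numbers for an effect only at larger amounts of compound), the highest of the three numbers measured so far. Compound 1 `Cc1nn(-c2ncnc3nc[nH]c23)c2c1C(OC1CCCC1)CC(=O)N2` gives 2 nM, and compound 2 `Cc1nn(-c2ncnc3nc[nH]c23)c2c1C(OCCn1nccc1C)CC(=O)N2` gives 10 nM. Compound 4 `Cc1nn(-c2ncnc3nc[nH]c23)c2c1C(OCCc1ccccc1)CC(=O)N2` differs from compound 3 in one place: phenethyloxy in place of methyl(phenyl)carbamoyl on a saturated ring carbon. Both earlier steps that swapped an oxygen-linked group for the carbamoyl bear on this change, namely a 16-fold higher number from compound 1 to compound 3 (1.20 log units; beyond the scatter) and a 3.2-fold higher number from compound 2 to compound 3 (0.51 log units; beyond the scatter). Compound 4 returns to an oxygen-linked group carrying a ring on a two-carbon chain, much as in compound 2, so the number is expected to fall below that of compound 3, by about a 4.0-fold lower number from compound 3 to compound 4 (0.60 log units; beyond the scatter). Compound 4 is therefore estimated at 8 nM in this assay, with a likely range from 3 nM to 25 nM.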

Compound 4, half-maximal effective concentration: 3 nM
For compound 4 the middle estimate is 2.7-fold (0.43 log units) above the measured one; the measured number falls inside the stated range.
By their numbers in this assay, from the lowest: compounds 1 and 4 (each within the scatter of the next); then compound 2; then compound 3.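

Putting phenethyloxy in place of methyl(phenyl)carbamoyl on the saturated ring carbon gives an 11-fold lower number from compound 3 to compound 4 (1.03 log units; beyond the scatter) even though both groups carry a six-membered aromatic ring of carbon only, so the link to this carbon matters here and not merely the presence of that ring. At the far end of the chain, phenyl in place of 5-methyl-1H-pyrazol-1-yl gives a 3.3-fold lower number from compound 2 to compound 4 (0.52 log units; beyond the scatter) and so also counts. Phenethyl in place of cyclopentyl on the oxygen gives a 1.5-fold higher number from compound 1 to compound 4 (0.18 log units; within the scatter) and leaves these two groups indistinguishable.

From the compounds shown here alone, whether an amine on the phenyl ring or a longer chain before it would keep such low numbers remains open. Nothing given here explains any of these differences.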